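Replacing the furan arm of compound 2

This account rests on a few compounds, and the source may have more. Where it says the series, first, only, none or still open, it means among the compounds named here.

Compound 1 `COc1cccc(CNc2nc(Nc3ccc(N4CCN(C)CC4)cn3)ncc2Cl)c1`: 16200 nM
Compound 2 `CN1CCN(c2ccc(Nc3ncc(Cl)c(NCc4ccco4)n3)nc2)CC1`: 45700 nM

In an ADME assay on L02 cells (Homo sapiens) for inhibition, read by CCK-8 assay, with a stated time of 48 h (a higher number here means a weaker inhibitor of growth, a lower number a stronger inhibitor of growth), compound 2, at 45700 nM, holds the higher of the two numbers. Compound 3 `CC(C)c1ccc(Nc2nc(Nc3ccc(N4CCN(C)CC4)cn3)ncc2Cl)cc1` differs from it in one place: 4-isopropylphenyl in place of (furan-2-yl)methyl on a nitrogen on an aromatic ring. This puts 4-isopropylphenyl in place of (furan-2-yl)methyl on a nitrogen on an aromatic ring.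

Going by the values given here, only one measured step bears on this change, and only in part. It is a modest step beyond the scatter, a 2.8-fold higher number from compound 1 to compound 2 (0.45 log units; beyond the scatter), with furan-2-yl in place of 3-methoxyphenyl on a saturated chain carbon bound to a nitrogen on an aromatic ring. Compound 3 also swaps the furan for a six-membered aromatic ring of carbon only, so that step, read in reverse, suggests a lower number. Among the compounds with values here, no measured compound has its ring bound directly to that nitrogen, so the range stays wide. A similar drop is expected, a 3.3-fold lower number from compound 2 to compound 3 (0.51 log units; beyond the scatter). For compound 3 the estimate is 14000 nM, with an expected range of 4000 nM to 40000 nM.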

Compound 3, concentration for 50% growth inhibition: 13700 nM
For compound 3 the middle estimate is 1.0-fold (0.01 log units) above the measured one; measured number inside the range.
By their numbers in this assay, from the lowest: compounds 3 and 1 (each within the scatter of the next); then compound 2.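

In this assay, the (4-isopropylphenyl)amino arm gives a clear change from the ((furan-2-yl)methyl)amino arm (a 3.3-fold lower number from compound 2 to compound 3 (0.52 log units; beyond the scatter)), which shows that a six-membered aromatic ring of carbon only can stand on this nitrogen with no saturated chain carbon in the arm. Against the 3-methoxybenzyl arm, the same group gives a 1.2-fold lower number from compound 1 to compound 3 (0.07 log units; within the scatter), so compound 1 and compound 3 cannot be told apart here, and among these three compounds only compound 2 stands apart. Nothing given here accounts for these numbers.

As far as these compounds go, whether the isopropyl group or the directly bound ring sets the number of compound 3 stays open. So does what a plain phenyl ring, a 4-methoxyphenyl ring or a morpholine on this nitrogen would give.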